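The source may hold more compounds than are shown below. What is called first, only, known or untested is meant among the compounds shown, and "the series" means these compounds.

Measured in a functional assay on K562 cells (Homo sapiens), read by MTT assay, with a stated time of 72 h; a higher number here means a weaker inhibitor, a lower number a stronger inhibitor:
- Compound 1 `CNc1ncnc2c1c(-c1ccoc1)cn2[C@@H]1O[C@H](CO)[C@@H](O)[C@H]1O`: > 20000 nM (a limit)
- Compound 2 `Nc1nc(N)c2c(-c3cc4ccccc4o3)cn([C@@H]3O[C@H](CO)[C@@H](O)[C@H]3O)c2n1`: > 20000 nM (a limit)
- Compound 3 `Cc1nc(N)c2c(-c3ccoc3)cn([C@@H]3O[C@H](CO)[C@@H](O)[C@H]3O)c2n1`: > 20000 nM (a limit)

None of these three entries is a true number, and together they come to the limit of > 20000 nM in this assay, at which 3 of the 3 values shown sit. Compound 3 therefore has no exact position, and all that is known is its limit of > 20000 nM.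

Compound 4 `C#Cc1cn([C@@H]2O[C@H](CO)[C@@H](O)[C@H]2O)c2nc(C)nc(N)c12` keeps the core of compound 3 and carries ethynyl in place of furan-3-yl on an aromatic carbon. For the measured compounds named here, no pair of measured compounds differs in one place, so nothing here shows directly what such a change does in this assay. With so little to go on, the most likely outcomes are that compound 4 also stays at the limit or that it comes out as a modestly stronger inhibitor, with a lower number. The expected change is an at least 1.6-fold lower number from compound 3 to compound 4 (0.22 log units; that floor lies within the scatter), an estimate that is uncertain because compound 3 has only a limit to start from. For compound 4 the estimated value is 12000 nM, with an expected range from 1500 nM to 20000 nM.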

Compound 4, half-maximal inhibitory concentration: 3290 nM
For compound 4 the middle estimate is 3.6-fold (0.56 log units) above the measured one; measured number inside the range.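

In this assay the change from furan-3-yl to ethynyl on this aromatic carbon gives an at least 6.0-fold lower number from compound 3 to compound 4 (0.78 log units; beyond the scatter) and brings a true number out of a set that otherwise sits at a limit. The size of this step is only a floor, since compound 3 starts from a limit and not from a number: the limit of > 20000 nM in this assay, at which 3 of the 4 values shown sit. So the group on this carbon of the shared core can decide whether the compound gives a measurable value at all in this assay, which the earlier compounds could not show.

The compounds shown leave open whether the gain comes from having ethynyl on this carbon or simply from losing furan-3-yl. A nitrile, an amine or a longer alkyne chain on the same carbon of the core of compound 4 would help separate these two readings.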